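This account rests on a few compounds, and the source may have more. Where it says the series, first, only, none or still open, it means among the compounds named here.

Working notes on the series, read in a functional assay on PC-3 cells (Homo sapiens) for inhibition, read by MTT assay, with a stated time of 48 h, tested at 10 uM; a lower number here means less inhibition of growth, a higher number more inhibition of growth at the concentration tested:

- compound 1 `Cc1cc(=O)c2c(O)cc(OCc3ccco3)c([C@H]3CCN(C)C[C@H]3O)c2o1`: 14%
- compound 2 `Cc1oc2c([C@H]3CCN(C)C[C@H]3O)c(O)cc(O)c2c(=O)c1C(O)c1ccc(Cl)cc1`: 41%
- compound 3 `Cc1oc2c([C@H]3CCN(C)C[C@H]3O)c(O)cc(O)c2c(=O)c1C(O)c1ccccc1Br`: 45%

Compound 3, at 45%, carries the largest of the three numbers, but it cannot be separated from compound 2, since the step of a number 4 percentage points higher from compound 2 to compound 3 (within the scatter) does not exceed the usual spread of repeat measurements. Compound 1 lies well short of this pair, with a gap beyond the scatter. No change at a single place links compound 1 to either of the other two, so it offers no guide here.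

The next compound to read is compound 4 `Cc1oc2c([C@H]3CCN(C)C[C@H]3O)c(O)cc(O)c2c(=O)c1C(O)c1c(F)cccc1Cl`, which has 2-chloro-6-fluorophenyl in place of 2-bromophenyl on a saturated chain carbon bound to an aromatic carbon and an oxygen on a saturated carbon.

Going by the values given here, one measured step bears on this change, since it swaps one substituted phenyl for another at the same place: a number 4 percentage points higher from compound 2 to compound 3 (within the scatter). Among the compounds with values here, that is a single small step, and the data hold no example with this particular group. No shift beyond the scatter is therefore expected in this assay, and no direction can be firmly assigned. The expected change is small, a number 2 percentage points lower from compound 3 to compound 4 (within the scatter). The estimate for compound 4 is 43%, with an expected range of 31% to 55%.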

Compound 4, percent growth inhibition at one concentration: 0%
Compound 4: the middle estimate sits 43 percentage points above what was measured; the measured number lies below the stated range.
By their numbers in this assay, from the lowest: compound 4; then compound 1; then compounds 2 and 3 (each within the scatter of the next).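

In this assay, the group on a saturated chain carbon bound to an aromatic carbon and an oxygen on a saturated carbon proves not to be freely interchangeable: 2-chloro-6-fluorophenyl in place of 2-bromophenyl gives a number 45 percentage points lower from compound 3 to compound 4 (beyond the scatter), and in place of 4-chlorophenyl it gives a number 41 percentage points lower from compound 2 to compound 4 (beyond the scatter). Going by these compounds alone, the only earlier step at this place, a number 4 percentage points higher from compound 2 to compound 3 (within the scatter), suggested a flat position, but compound 4 shows that one aryl group here can remove all growth inhibition seen at the concentration tested, so the two earlier compounds sampled only part of what this place allows. No measurement at hand accounts for the loss.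

The compounds shown do not separate the contributions of the chlorine and the fluorine in 2-chloro-6-fluorophenyl, and 2-fluorophenyl, 2-chlorophenyl or unsubstituted phenyl at the same place would help show which feature goes with the loss. A single concentration also leaves open whether compound 4 has any effect on growth at higher concentrations, and whether the result holds beyond this one cell line.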